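Moving a hydroxyl around on a three-ring scaffold

This account rests on a few compounds, and the source may have more. Where it says the series, first, only, none or still open, it means among the compounds named here.

Compound 2 `Oc1ccc(-c2cc(-c3cccc(O)c3)nc(-c3cccc(O)c3)c2)cc1` is the stronger of the two measured compounds in an ADME assay on HEK293 cells (Homo sapiens) for cytotoxicity, read by CCK-8 assay, with a stated time of 4 days; a lower number here means a stronger inhibitor, a higher number a weaker inhibitor. In this assay compound 2 gives 730 nM, the lowest number of the pair. Going by the values given here, compound 1 `Oc1ccc(-c2cc(-c3ccccc3O)cc(-c3cccc(O)c3)n2)cc1`, which carries its three hydroxyphenyl groups in a different arrangement around the shared core, gives 5650 nM in this assay; the two compounds differ in more than one place, so no single step connects them, and the gap between them is beyond the usual scatter.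

Compound 3 `Oc1cccc(-c2cc(-c3ccccc3O)cc(-c3cccc(O)c3)n2)c1` is the next compound to be measured. It has the same atoms as compound 2, joined differently: 2-hydroxyphenyl in place of 4-hydroxyphenyl on an aromatic carbon. Among the compounds with values here, no measured pair shows this exact change, so the expected step is drawn from the two values in hand. Since compound 1, which also carries a 2-hydroxyphenyl group, gives 5650 nM, a weakening from compound 2 to compound 3 of a 2.7-fold higher number from compound 2 to compound 3 (0.44 log units; beyond the scatter) is expected, beyond the scatter but not by a wide margin. Compound 3 is therefore estimated at 2000 nM in this assay, with a likely range from 700 nM to 6000 nM.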

Compound 3, half-maximal inhibitory concentration: 130 nM
Compound 3: the middle estimate sits 15-fold (1.19 log units) above what was measured; measured number below the stated range.
By their numbers in this assay, from the lowest: compound 3; then compound 2; then compound 1.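

In this assay, 2-hydroxyphenyl in place of 4-hydroxyphenyl on the aromatic carbon opposite the ring nitrogen gives a 5.6-fold lower number from compound 2 to compound 3 (0.75 log units; beyond the scatter), so the number at this position falls with this change instead of rising. The earlier compounds shown here could not show this: compound 1 and compound 2 differ in more than one place, so the high value of compound 1 said nothing about 2-hydroxyphenyl taken alone. The second step, 3-hydroxyphenyl in place of 4-hydroxyphenyl with 2-hydroxyphenyl kept opposite the ring nitrogen, gives a 43-fold lower number from compound 1 to compound 3 (1.64 log units; beyond the scatter), a large change that shows how much the outcome can hang on where a single hydroxyl sits on one ring of this scaffold.

No separate measurement among these compounds bears on why either change lowers the number. Going by these compounds, what remains open is whether the hydroxyl itself matters at these positions, a question that a methoxy group, an amine or a carboxylic acid in its place, or a plain phenyl ring with no hydroxyl, could begin to answer.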